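Thiophen-3-yl in Place of 1-Benzofuran-2-yl, Second Pair

The compounds below may be only part of what the source reports. "The series", "measured", "known", "first", "only" and "open" are said of these compounds alone.

Compound 1 `O=c1[nH]cnc2c1c(-c1ccsc1)cn2[C@@H]1O[C@H](CO)[C@@H](O)[C@H]1O`: > 20000 nM in a functional assay on HCT-116 cells (Homo sapiens), read by MTT assay, with a stated time of 72 h (a higher number here means a weaker inhibitor, a lower number a stronger inhibitor), a limit of the assay.
Compound 2 `O=c1[nH]cnc2c1c(-c1cc3ccccc3o1)cn2[C@@H]1O[C@H](CO)[C@@H](O)[C@H]1O`: > 20000 nM, likewise a limit.
Compound 3 `Cc1nc(N)c2c(-c3cc4ccccc4o3)cn([C@@H]3O[C@H](CO)[C@@H](O)[C@H]3O)c2n1`: 13100 nM.

Compound 1 and compound 2 share one core and differ only by thiophen-3-yl in place of 1-benzofuran-2-yl on an aromatic carbon. The step that the two limits leave unreadable from compound 2 to compound 1 cannot be read, because of the limit of > 20000 nM in this assay, at which 2 of the 3 values shown sit.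

Compound 3 carries a different core; how that core differs from the core of compound 2 is not broken down here. Compound 3 is the only one of the three with a number rather than a limit.

Compound 4 `Cc1nc(N)c2c(-c3ccsc3)cn([C@@H]3O[C@H](CO)[C@@H](O)[C@H]3O)c2n1` has not yet been measured in this assay. It differs from compound 3 by thiophen-3-yl in place of 1-benzofuran-2-yl on an aromatic carbon, the same change as that from compound 2 to compound 1, made on the same kind of place. Since the earlier pair gives no readable size, the expected step of a 1.4-fold higher number from compound 3 to compound 4 (0.14 log units; within the scatter) rests only on the value of compound 3 13100 nM. Compound 4 is expected at 18000 nM, within 7000 nM to 45000 nM, with a real chance that only a limit is reported.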

Compound 4, half-maximal inhibitory concentration: > 20000 nM
Compound 4: a limit, no number (the forecaster's own chance of this, stated with the estimate: 55%); middle value at least 1.1-fold (0.04 log units) away from the limit.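

In this assay, thiophen-3-yl in place of 1-benzofuran-2-yl on the core of compound 3 gives an at least 1.5-fold higher number from compound 3 to compound 4 (0.18 log units; that floor lies within the scatter). This reading is only a floor, and it lies within the scatter, so it does not establish a real loss on this core, and it gives no true size for the change. Whether the change carries over from one core to the other cannot be judged, because the step on the core of compound 1 and compound 2 cannot be read, and the new step has no readable size to set against it: the limit of > 20000 nM in this assay, at which 3 of the 4 values shown sit.

The compounds shown leave open what other groups on this aromatic carbon would do on the core of compound 3, such as a phenyl ring, a furan-2-yl ring, an aminomethyl group or a carboxylic acid. They also leave open whether a group other than the methyl and the amine of that core would bring the thiophen-3-yl compound within the measurable range.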